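The source may hold more compounds than are shown below. What is called first, only, known or untested is meant among the compounds shown, and "the series" means these compounds.

Working notes on the shared core with its ethyl ester, all tested in a functional assay on HCT-116 cells (Homo sapiens) for inhibition, read by MTT assay, with a stated time of 72 h; a lower number here means a stronger inhibitor, a higher number a weaker inhibitor. Compound 1 `CCOC(=O)c1oc2ccc(NS(=O)(=O)c3ccc(Br)cc3)cc2c1C` gives 9310 nM in this assay. Compound 2 `CCOC(=O)c1oc2ccc(N(Cc3ccccc3)S(=O)(=O)c3ccc(Br)cc3)cc2c1C` gives 9460 nM in this assay; the step of a 1.0-fold higher number from compound 1 to compound 2 (0.01 log units; within the scatter) leaves the number where it was. Compound 3 `CCOC(=O)c1oc2ccc(N(Cc3ccccc3)S(=O)(=O)c3ccc(C)cc3)cc2c1C` is reported in this assay only as a limit, > 40000 nM. That figure is the limit of the assay, (the limit of > 40000 nM in this assay, at which 1 of the 3 values shown sits), so compound 3 stands at the weak end of what has been shown and its true number is not known. Among the compounds with values here, the step of an at least 4.2-fold higher number from compound 2 to compound 3 (0.62 log units; beyond the scatter) is the one measured change at this para position, and it weakened inhibition beyond the scatter.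

Compound 4 `CCOC(=O)c1oc2ccc(N(Cc3ccccc3)S(=O)(=O)c3ccc(Cl)cc3)cc2c1C` is not yet measured. Its difference from compound 3 reads: chloro in place of methyl on an aromatic carbon. Within the data shown here, the only step that bears on it is an at least 4.2-fold higher number from compound 2 to compound 3 (0.62 log units; beyond the scatter), in which bromo gave way to methyl at the same place; compound 4 carries chloro there, as compound 2 carries bromo, so the reverse sense of that step is expected, with a gain in this assay of modest size, the exact figure uncertain since compound 3 has only a limit. Compound 4 is expected at 15000 nM, within 6000 nM to 45000 nM. The estimated step is an at least 2.6-fold lower number from compound 3 to compound 4 (0.42 log units; beyond the scatter).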

Compound 4, half-maximal inhibitory concentration: 4860 nM
Estimate against measurement, compound 4: 3.1-fold (0.49 log units) above; measured number outside the range, below it.
By their numbers in this assay, from the lowest: compounds 4, 1 and 2 (each within the scatter of the next). At a limit, above all of these: compound 3.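

In this assay, the change from 4-methylphenyl to 4-chlorophenyl gives an at least 8.2-fold lower number from compound 3 to compound 4 (0.91 log units; beyond the scatter), so this place, para to a large group, now has a second measured change, and it runs opposite to the change from bromo to methyl. The comparison between the two halogens gives a 1.9-fold lower number from compound 2 to compound 4 (0.29 log units; within the scatter), so chloro and bromo cannot be told apart here, and among compounds 2, 3 and 4, only the methyl of compound 3 goes with the loss of inhibition, though three compounds carry this pattern no further than these groups. On these data alone, the true size of the step from methyl to chloro remains unknown because compound 3 is held only at a limit of the assay: the limit of > 40000 nM in this assay, at which 1 of the 4 values shown sits.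

As far as these compounds go, whether the response at this place extends beyond chloro and bromo remains open, and a methoxy group, a nitrile or a trifluoromethyl group there would test whether methyl is a lone exception. Also open, from the compounds shown here alone, is whether a 1.0-fold higher number from compound 1 to compound 2 (0.01 log units; within the scatter), read so far only with bromo in place, holds with chloro, and whether a carboxylic acid in place of the ethyl ester on the shared core would alter these numbers.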